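A Trifluoromethyl Added to a Triazole-Linked Phenol

The compounds below may be only part of what the source reports. "The series", "measured", "known", "first", "only" and "open" are said of these compounds alone.

Compound 1 `Cc1c(O)ccc2c1[C@H](Cn1cc(-c3ccccc3)nn1)[C@@]13CC(=O)[C@@](C)(CC[C@@H]21)C3` was tested in a functional assay on A549 cells (Homo sapiens) for cytotoxicity, read by MTT assay, with a stated time of 4 days (a lower number here means a stronger inhibitor, a higher number a weaker inhibitor), and gave only a limit of the assay, > 20000 nM. Its sulfonyl ester, compound 2 `Cc1ccc(S(=O)(=O)Oc2ccc3c(c2C)[C@H](Cn2cc(-c4ccccc4)nn2)[C@@]24CC(=O)[C@@](C)(CC[C@@H]32)C4)cc1`, also reached only a limit, > 20000 nM. The related compound 3 `C=C1C(=O)[C@]23C[C@@]1(O)CC[C@H]2c1ccc(O)c(C)c1[C@@H]3Cn1cc(-c2ccccn2)nn1`, which differs in several places, gives 1570 nM in this assay. Among the compounds with values here, the only single-point step among the measured compounds, a step that the two limits leave unreadable from compound 1 to compound 2, cannot be read, because the limit of > 20000 nM in this assay, at which 2 of the 3 values shown sit, hides both ends. Compound 4 `Cc1c(O)ccc2c1[C@H](Cn1cc(-c3ccc(C(F)(F)F)cc3)nn1)[C@@]13CC(=O)[C@@](C)(CC[C@@H]21)C3` differs from compound 1 by trifluoromethyl in place of hydrogen on an aromatic carbon. Within the data shown here, no measured step speaks to this change, and compound 1 itself sits at a limit, so no direction beyond the scatter is expected; a step of about a number no higher from compound 1 to compound 4 (the limit leaves the size open) is estimated. Compound 4 is therefore expected near 20000 nM, within 5000 nM to 60000 nM.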

Compound 4, half-maximal inhibitory concentration: > 20000 nM
Compound 4: only a limit was reported (the forecaster's own chance of this, stated with the estimate: 60%); the middle value lies on the limit itself.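

Within the data shown here, compound 4 also gives only a limit of the assay, so no step from compound 1 to compound 4 can be read: the limit of > 20000 nM in this assay, at which 3 of the 4 values shown sit.
The compounds shown leave open whether trifluoromethyl in place of hydrogen changes anything in this assay.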